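Hydroxy for chloro on the aryl imine of compound 2

The source may hold more compounds than are shown below. What is called first, only, known or untested is meant among the compounds shown, and "the series" means these compounds.

Two compounds of the series have numbers in an ADME assay on HepG2 cells (Homo sapiens) for cytotoxicity, read by MTT assay, with a stated time of 72 h; on this read-out higher numbers stand for lower toxicity in this test and lower numbers for higher toxicity in this test. Compound 1 `Oc1ccccc1/C=N/c1sc2c(c1-c1nc3ccccc3s1)CCC2` gives 156 ug/mL in this assay. Compound 2 `Clc1ccccc1/C=N/c1sc2c(c1-c1nc3ccccc3s1)CCCC2` gives 370 ug/mL in this assay, the highest of the two numbers; its nearest neighbour is compound 1, whose number is lower by a gap beyond the scatter. Among the measured compounds shown here, compound 1 and compound 2 differ in more than one place, so no single step connects them and only their two values can be compared.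

Compound 3 `Oc1ccccc1/C=N/c1sc2c(c1-c1nc3ccccc3s1)CCCC2` is not yet measured in this assay. It differs from compound 2 by hydroxy in place of chloro on an aromatic carbon. Compound 1 carries the same hydroxy and gives 156 ug/mL in this assay, so a downward step of moderate size is expected for the step from compound 2 to compound 3, a 1.8-fold lower number from compound 2 to compound 3 (0.25 log units; within the scatter), near the edge of the scatter. For compound 3 the expected value in this assay is 210 ug/mL, with a range from 100 ug/mL to 420 ug/mL.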

Compound 3, half-maximal cytotoxic concentration: 114 ug/mL
Compound 3: middle estimate off by 1.8-fold (0.27 log units), on the high side, and the stated range covers the measured number.
By their numbers in this assay, from the lowest: compounds 3 and 1 (each within the scatter of the next); then compound 2.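

The change from 2-chlorophenyl to 2-hydroxyphenyl now has a step of its own in this assay, with a 3.2-fold lower number from compound 2 to compound 3 (0.51 log units; beyond the scatter) as the single readable move at this aromatic carbon. The earlier gap between compound 1 and compound 2 mixed this change with a second difference, whereas this step shows that hydroxy in place of chloro is enough on its own to carry the number beyond the scatter. Among the hydroxy compounds, compound 3 at 114 ug/mL and compound 1 at 156 ug/mL are within the scatter of each other, so the other place shows no readable effect between these two.

From the compounds shown here alone, whether a methoxy, an amine or a fluoro on the same aromatic carbon would sit with hydroxy or with chloro stays open. No measurement shown here bears on what lies behind the step.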